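The source may hold more compounds than are shown below. What is called first, only, known or untested is meant among the compounds shown, and "the series" means these compounds.

In a functional assay on PC-3 cells (Homo sapiens) for inhibition, read by MTT assay, with a stated time of 48 h (on this read-out higher numbers stand for weaker inhibition and lower numbers for stronger inhibition), compound 1 `COc1ccc(CSc2nnc(-c3cc(OC)c(OC)c(OC)c3)n2-c2ccc(OC)cc2)cc1` gives 40300 nM. Compound 2 `COc1ccc(-n2c(SCC(=O)c3ccc4ccccc4c3)nnc2-c2cc(OC)c(OC)c(OC)c2)cc1` gives > 60000 nM, which is a limit of the assay and not a number. Compound 3 `COc1ccc(NC(=O)CSc2nnc(-c3cc(OC)c(OC)c(OC)c3)n2-c2ccc(OC)cc2)cc1` has (4-methoxyphenyl)amino in place of naphthalen-2-yl on a carbonyl carbon. Within the data shown here, the only measured step, an at least 1.4-fold higher number from compound 1 to compound 2 (0.17 log units; that floor lies within the scatter), changes a different group and has a floor within the scatter, so it offers a weak guide. In this assay, only a modest move to a lower number is therefore expected, and the expected step is an at least 1.5-fold lower number from compound 2 to compound 3 (0.19 log units; that floor lies within the scatter). For compound 3, the estimated value is 38000 nM, with an expected range of 15000 nM to 60000 nM.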

Compound 3, half-maximal inhibitory concentration: 25800 nM
Estimate against measurement, compound 3: 1.5-fold (0.17 log units) above; measured number inside the range.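

In this assay, placing (4-methoxyphenyl)amino instead of naphthalen-2-yl on the carbonyl carbon gives an at least 2.3-fold lower number from compound 2 to compound 3 (0.36 log units; beyond the scatter). On these data alone, compound 2 stands at a limit of the assay and not a number, so the true size of this step remains unknown: the limit of > 60000 nM in this assay, at which 1 of the 3 values shown sits. Replacing 4-methoxyphenyl with (4-methoxyphenyl)carbamoyl on the saturated chain carbon bound to a sulfur gives only a 1.6-fold lower number from compound 1 to compound 3 (0.19 log units; within the scatter), so compound 1 and compound 3 cannot be told apart here.

As far as these compounds go, it remains open whether the amide hydrogen or the methoxy group matters at this position. A phenylamino group on the same carbonyl carbon would help separate the two.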